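Methoxy on the lactone methyl of compound 2

The compounds below may be only part of what the source reports. "The series", "measured", "known", "first", "only" and "open" are said of these compounds alone.

Measured so far:
compound 1 `C=C1C(=O)O[C@@H]2/C=C(\C)CCC[C@H](C)CC[C@H]12` — 27 ug/mL
compound 2 `C/C1=C\[C@H]2OC(=O)[C@@H](C)[C@@H]2CC/C(C)=C/CC1` — 134 ug/mL

In a functional assay on COLO 205 cells (Homo sapiens) for cytotoxicity, read by MTT assay, with a stated time of 48 h (a lower number here means a stronger inhibitor, a higher number a weaker inhibitor), compound 2 gives 134 ug/mL and stands highest of the two numbers; compound 1 gives 27 ug/mL, a lower number beyond the scatter. Compound 3 `COC[C@@H]1C(=O)O[C@@H]2/C=C(\C)CC/C=C(\C)CC[C@@H]12` is not yet measured. It differs from compound 2 as follows: methoxy in place of hydrogen on a saturated chain carbon bound to a saturated ring carbon. Within the data shown here, no step between measured compounds that matches this change is available, so the direction rests on little. The change from compound 2 to compound 3, a 1.3-fold lower number from compound 2 to compound 3 (0.13 log units; within the scatter), is expected to be small and to stay within the scatter, with a modest drift toward a lower number. Compound 3 is expected at 100 ug/mL, range 40 ug/mL to 250 ug/mL.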

Compound 3, half-maximal inhibitory concentration: 220 ug/mL
The estimate for compound 3 lay 2.2-fold (0.34 log units) below the measured number; low and high end bracket the measured number.
By their numbers in this assay, from the lowest: compound 1; then compounds 2 and 3 (each within the scatter of the next).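

In this assay, among these compounds, the first step at this position, methyl to methoxymethyl on a saturated chain carbon bound to a saturated ring carbon, reads a 1.6-fold higher number from compound 2 to compound 3 (0.22 log units; within the scatter) and so gives no separable difference. On this single step, the position accepts methoxy in place of hydrogen with the number staying inside the scatter. No measurement at hand bears on a reason for this result. Still open, from the compounds shown here alone, is how an amine or a carboxylic acid would read at this place, and whether methoxy behaves alike on the core of compound 1.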